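A Methoxyphenyl Triazole Lactone Awaits Its Antiproliferative Readout

A few compounds are considered here, and "the series" means these few. Any claim that something is new, unique, unknown or untested is made for them only; others in the source may bear on it.

Compound 1, `CCCCCc1ccc(-c2cn(C/C=C3\OC(=O)C(OCc4ccccc4)=C3OCc3ccccc3)nn2)cc1`, gives > 100000 nM in a functional assay on SW-620 cells (Homo sapiens) for antiproliferative activity, read by MTT assay, with a stated time of 72 h (a lower number here means a stronger inhibitor, a higher number a weaker inhibitor), which is a limit of the assay rather than a number.
Compound 2, `CC(C)(C)OC(=O)N1CCN(C(=S)SCc2cn(C[C@H](O)[C@H]3OC(=O)C(OCc4ccccc4)=C3OCc3ccccc3)nn2)CC1`, gives > 100000 nM in this assay, again a limit.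
Compound 3, `CC(C)(C)c1cn(C[C@H](O)[C@H]2OC(=O)C(OCc3ccccc3)=C2OCc2ccccc2)nn1`, gives 35800 nM in this assay.

Going by the values given here, compound 3 therefore stands alone as the only member of the set with a measured number; the other two sit at the limit of > 100000 nM in this assay, at which 2 of the 3 values shown sit, so no ordering among the three can be drawn beyond saying that compound 3 yields a value where the others do not. Compound 4, `COc1ccc(-c2cn(C[C@H](O)[C@H]3OC(=O)C(OCc4ccccc4)=C3OCc3ccccc3)nn2)cc1`, is the compound still to be measured. It differs from compound 3 by 4-methoxyphenyl in place of tert-butyl on an aromatic carbon. Among the compounds with values here, no measured pair isolates this exchange. Within the data shown here, compound 1 also bears an aryl group on the same five-membered ring, but it differs from compound 3 in its linker as well and gives only a limit, so it offers no step to lean on. The exchange is therefore expected to move the value by a 1.3-fold higher number from compound 3 to compound 4 (0.10 log units; within the scatter), a shift not clearly beyond the scatter. Compound 4 is estimated at 45000 nM, within 12000 nM to 150000 nM.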

Compound 4, half-maximal inhibitory concentration: 58200 nM
The estimate for compound 4 lay 1.3-fold (0.11 log units) below the measured number, and the stated range covers the measured number.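

In this assay, placing 4-methoxyphenyl in place of tert-butyl on an aromatic carbon of the five-membered aromatic ring gives a 1.6-fold higher number from compound 3 to compound 4 (0.21 log units; within the scatter). This is the first pair shown that isolates a change at this position, and it shows that a six-membered aromatic ring of carbon only, carrying a hydrogen-bond acceptor, can replace tert-butyl here with no difference that can be told from the scatter. Compounds 1 and 2 differ from this pair in more than one place and each gives a limit rather than a number: the limit of > 100000 nM in this assay, at which 2 of the 4 values shown sit.

The compounds shown leave open whether an amine, a carboxylic acid or a longer alkyl chain at this position would move the value beyond the scatter. Going by these compounds alone, they also leave open what the hydroxyl on the linker contributes, as no pair isolates it.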